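Thiophen-2-yl swap on the vinyl sulfonyl piperazine series

The source may hold more compounds than are shown below. What is called first, only, known or untested is meant among the compounds shown, and "the series" means these compounds.

- compound 1 `C=CS(=O)(=O)N1CCN(c2ncnc3sc(-c4ccccc4)cc23)CC1`: 21100 nM
- compound 2 `C=CS(=O)(=O)N1CCN(c2ncnc3sc(-c4ccc(OC)nc4)cc23)CC1`: 11900 nM
- compound 3 `C=CS(=O)(=O)N1CCN(c2ncnc3sc(-c4c(C)noc4C)cc23)CC1`: 34600 nM

All three values come from a functional assay on MDA-MB-436 cells (Homo sapiens) for antiproliferative activity, read by MTT assay, with a stated time of 48 h; on this read-out lower numbers stand for stronger inhibition and higher numbers for weaker inhibition. Compound 3 stands at the top of the range, though its nearest neighbour shows a 1.6-fold higher number from compound 1 to compound 3 (0.21 log units; within the scatter). The next analogue, compound 4 `C=CS(=O)(=O)N1CCN(c2ncnc3sc(-c4cccs4)cc23)CC1`, carries thiophen-2-yl in place of 3,5-dimethyl-1,2-oxazol-4-yl on an aromatic carbon.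

Swaps at this carbon have moved the number little, with a 1.8-fold lower number from compound 1 to compound 2 (0.25 log units; within the scatter). For the measured compounds named here, the only step beyond the scatter, a 2.9-fold higher number from compound 2 to compound 3 (0.46 log units; beyond the scatter), is modest. No thiophene has been measured yet, so in this assay a small move toward a lower number, probably within the scatter, is expected. The expected change is a 1.9-fold lower number from compound 3 to compound 4 (0.28 log units; within the scatter). For compound 4 the estimate is 18000 nM, with an expected range of 8000 nM to 40000 nM.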

Compound 4, half-maximal inhibitory concentration: 39000 nM
Beside the measured number, compound 4's estimate is 2.2-fold (0.34 log units) below it, within the range that was stated.
By their numbers in this assay, from the lowest: compounds 2, 1, 3 and 4 (each within the scatter of the next, the first and the last beyond it).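

In this assay thiophen-2-yl on this aromatic carbon, next to the ring sulfur, cannot be told apart from the other five-membered ring, with a 1.1-fold higher number from compound 3 to compound 4 (0.05 log units; within the scatter) within the scatter, or from phenyl, with a 1.8-fold higher number from compound 1 to compound 4 (0.27 log units; within the scatter) likewise within it. Only the 6-methoxypyridin-3-yl group stands apart, with a 3.3-fold higher number from compound 2 to compound 4 (0.52 log units; beyond the scatter) as a modest step, so both steps beyond the scatter at this carbon involve compound 2. No evidence available bears on this result.

The compounds shown leave open whether an amine or a carboxylic acid on the aromatic ring at this carbon would give a larger step. They also leave open whether the methoxy group or the pyridine nitrogen of compound 2 sets it apart.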